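Substituting the phenyl group on a shared core

The source may report more compounds than this note shows. Statements on the series, on what has been measured and on what is new or still open speak of the compounds shown alone.

Of the compounds shown here, three built on one shared core have been tested in a functional assay on K562 cells for agonist activity at integrin alpha-M/beta-2 (Homo sapiens); on this read-out lower numbers stand for an effect already at smaller amounts and higher numbers for an effect only at larger amounts of compound. Compound 1 `CCOC(=O)CN1C(=O)S/C(=C\c2ccc(N3CCCC3)o2)C1=O` carries a pyrrolidin-1-yl group and gives 23200 nM in this assay. Compound 2 `COC(=O)CN1C(=O)S/C(=C\c2ccc(Sc3ccccc3)o2)C1=O`, which bears a phenylthio group and a methyl ester, is reported as "not active" (no number reported) in this assay. Among the compounds with values here, compound 3 `CCOC(=O)CN1C(=O)S/C(=C\c2ccc(-c3ccccc3)o2)C1=O` carries a phenyl group at the same place and gives 10500 nM in this assay, the lowest of the two numbers measured so far; its nearest neighbour is compound 1, and the step of a 2.2-fold lower number from compound 1 to compound 3 (0.34 log units; beyond the scatter) is beyond the scatter.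

Compound 4 `CCOC(=O)CN1C(=O)S/C(=C\c2ccc(-c3ccc(C)cc3Br)o2)C1=O` has not yet been measured. It differs from compound 3 in one place: 2-bromo-4-methylphenyl in place of phenyl on an aromatic carbon. Within the data shown here, no measured step bears directly on this change. Among the measured compounds shown here, the only step available, a 2.2-fold lower number from compound 1 to compound 3 (0.34 log units; beyond the scatter), exchanges one whole group for another rather than altering the phenyl ring itself, and compound 2 shows only that a related aryl attachment can come out as inactive. One therefore expects a step of a 1.2-fold lower number from compound 3 to compound 4 (0.07 log units; within the scatter) of small size, in either direction, and not clearly beyond the scatter. For compound 4 the estimated value in this assay is 9000 nM, with a range from 2500 nM to 35000 nM.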

Compound 4, half-maximal effective concentration: 18600 nM
Compound 4: middle estimate off by 2.1-fold (0.32 log units), on the low side; the range from low to high includes it.
By their numbers in this assay, from the lowest: compounds 3, 4 and 1 (each within the scatter of the next, the first and the last beyond it).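

In this assay the phenyl ring on the aromatic carbon next to the ring oxygen takes on the bromine and the methyl of 2-bromo-4-methylphenyl with a 1.8-fold higher number from compound 3 to compound 4 (0.25 log units; within the scatter) as the result, so this larger aryl group, with 8 heavy atoms in place of 6, is tolerated at this place without a step that stands clear of the scatter. The comparison with the pyrrolidin-1-yl compound also shifts: where phenyl gave a step beyond the scatter (a 2.2-fold lower number from compound 1 to compound 3 (0.34 log units; beyond the scatter)), the new group gives a 1.2-fold lower number from compound 1 to compound 4 (0.10 log units; within the scatter) and cannot be told apart from pyrrolidin-1-yl at this place. Nothing in hand explains these numbers or says how this change acts at the receptor.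

The bromine and the methyl enter together, so the compounds shown do not separate what each contributes on its own, and compound 2 differs from the others in both the linking atom and the ester. From the compounds shown here alone, it also remains open how the read-out responds when the phenyl ring carries an amine or a carboxylic acid, or when a longer chain replaces the ethyl ester.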